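Aryl sulfonamide series: pyridin-3-yl analogue of compound 1

The source may hold more compounds than are shown below. What is called first, only, known or untested is meant among the compounds shown, and "the series" means these compounds.

Measured so far:
compound 1 `COc1ccc(S(=O)(=O)N2CCc3cccc(-c4ccc(N)cc4)c32)cc1` 288 nM
compound 2 `COc1ccc(S(=O)(=O)N2CCc3cccc(-c4ccc(F)nc4)c32)cc1` 135 nM
compound 3 `COc1ccc(S(=O)(=O)N2CCc3cccc(-c4ccc(F)cc4)c32)cc1` 95.5 nM

In a functional assay on NCI-H460 cells (Homo sapiens) for inhibition, with a stated time of 72 h (on this read-out lower numbers stand for stronger inhibition and higher numbers for weaker inhibition), compound 1 stands at the highest of the three numbers. Compound 2 lies nearest, a 2.1-fold lower number from compound 1 to compound 2 (0.33 log units; beyond the scatter), and compound 3 furthest, a 3.0-fold lower number from compound 1 to compound 3 (0.48 log units; beyond the scatter). Between compound 2 and compound 3 the step is a 1.4-fold lower number from compound 2 to compound 3 (0.15 log units; within the scatter).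

Compound 4 `COc1ccc(S(=O)(=O)N2CCc3cccc(-c4cccnc4)c32)cc1` has not been measured. It differs from compound 1 as follows: pyridin-3-yl in place of 4-aminophenyl on an aromatic carbon

Both measured steps from compound 1 bear on this change: in each the 4-aminophenyl group is removed, in one case for 6-fluoropyridin-3-yl a 2.1-fold lower number from compound 1 to compound 2 (0.33 log units; beyond the scatter), in the other for 4-fluorophenyl a 3.0-fold lower number from compound 1 to compound 3 (0.48 log units; beyond the scatter). Compound 4 likewise carries a pyridin-3-yl ring without the amino group, and so a modest lowering of the number is expected, of about the size seen in the step to compound 2, estimated as a 1.9-fold lower number from compound 1 to compound 4 (0.28 log units; within the scatter). For compound 4 the expected value in this assay is 150 nM, with a range of 70 nM to 320 nM.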

Compound 4, half-maximal inhibitory concentration: 89.6 nM
For compound 4 the middle estimate is 1.7-fold (0.22 log units) above the measured one, and the stated range covers the measured number.
By their numbers in this assay, from the lowest: compounds 4, 3 and 2 (each within the scatter of the next); then compound 1.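

In this assay, the unsubstituted pyridin-3-yl ring gives the largest step of the series (a 3.2-fold lower number from compound 1 to compound 4 (0.51 log units; beyond the scatter)), so the fluoro of compound 2 is not required for the shift away from compound 1. Removing that fluoro (a 1.5-fold lower number from compound 2 to compound 4 (0.18 log units; within the scatter)) and exchanging 4-fluorophenyl for pyridin-3-yl (a 1.1-fold lower number from compound 3 to compound 4 (0.03 log units; within the scatter)) both stay within the scatter, so compounds 2, 3 and 4 cannot be told apart at this position, and only the 4-aminophenyl of compound 1 stands apart from them. No measurement at hand bears on the cause of these steps.

Open, from the compounds shown here alone, is whether the amino group alone sets compound 1 apart, which an unsubstituted phenyl or a 4-hydroxyphenyl ring would test. Also open, going by these compounds, is how a pyridin-4-yl ring or a saturated amine such as piperidine would read here.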